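Methyl on the pendant phenyl across two cores

The source may report more compounds than this note shows. Statements on the series, on what has been measured and on what is new or still open speak of the compounds shown alone.

Compound 1 `C/C(=C\c1cc(-c2ccccc2)co1)C(N)=O` carries an unsubstituted phenyl on its core; in a functional assay on HeLa cells (Homo sapiens) for cytotoxicity, read by CCK-8 assay, with a stated time of 24 h (a higher number here means a weaker inhibitor, a lower number a stronger inhibitor), compound 1 gives 3280 nM. Compound 2 `C/C(=C\c1cc(-c2ccc(C)cc2)co1)C(N)=O` differs from it by methyl in place of hydrogen on an aromatic carbon and in this assay compound 2 gives 12000 nM, a step of a 3.7-fold higher number from compound 1 to compound 2 (0.56 log units; beyond the scatter). Compound 3 `C/C(=C\c1cc(-c2ccccc2)cs1)C(N)=O` is built on a different core; the difference between the two cores is not broken down here. In this assay compound 3 gives 12700 nM, which lies within the scatter of compound 2 and is a higher number than compound 1.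

Compound 4 `C/C(=C\c1cc(-c2ccccc2C)cs1)C(N)=O` is not yet measured and differs from compound 3 by methyl in place of hydrogen on an aromatic carbon. For the measured compounds named here, this is the same kind of change as the one between compound 1 and compound 2, but not the same: there the methyl sits para to a large group, here ortho to a large group, and on the other core. A step in the same direction is expected for compound 4, a 2.0-fold higher number from compound 3 to compound 4 (0.29 log units; within the scatter), because the earlier methyl gave a 3.7-fold higher number from compound 1 to compound 2 (0.56 log units; beyond the scatter). The changed place and core leave the size uncertain. In this assay compound 4 is expected to give 25000 nM, between 9000 nM and 70000 nM.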

Compound 4, half-maximal inhibitory concentration: 19400 nM
The estimate for compound 4 lay 1.3-fold (0.11 log units) above the measured number; measured number inside the range.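

In this assay, methyl in place of hydrogen on the core of compound 3, ortho to a large group, gives a 1.5-fold higher number from compound 3 to compound 4 (0.18 log units; within the scatter), a step that does not stand clear of the scatter. Set beside the step on the other core, it shows no measurable difference between the two: the same change on two cores in this assay, a 3.7-fold higher number (0.56 log units; beyond the scatter) from compound 1 to compound 2 and a 1.5-fold higher number (0.18 log units; within the scatter) from compound 3 to compound 4, 2.4-fold (0.38 log units) apart, within the scatter of two such steps. The data therefore give no sign that the core alters this change, but they do not show that it carries over unaltered, since the earlier step stood beyond the scatter, the later one within it, and the methyl holds a different place on each core, so core and place cannot be separated.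

Still open, as far as these compounds go, is how a methyl ortho to a large group would read on the core of compound 1, and how the methyl placement of compound 2 would read on the core of compound 3. Also open, from the compounds shown here alone, is how either core would respond to a methoxy, an amine or a carboxylic acid on the pendant phenyl in place of methyl.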